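From propanoyl to ethoxycarbonyl on the shared core

A few compounds are considered here, and "the series" means these few. Any claim that something is new, unique, unknown or untested is made for them only; others in the source may bear on it.

Measured so far in a toxicity assay on NIH3T3 cells (Mus musculus) for cytotoxicity, read by resazurin assay (on this read-out higher numbers stand for an effect only at larger amounts of compound and lower numbers for an effect already at smaller amounts), for cytotoxicity:
compound 1 `O=C(c1ccc(NCc2cncn2Cc2ccc(-c3ccccc3)cc2)cc1-c1ccccc1)N1CCCCC1` gives > 1000 nM
compound 2 `CCC(=O)c1ccc(NCc2cncn2Cc2ccc(-c3ccccc3)cc2)cc1-c1ccccc1` gives > 10000 nM

Both entries are limits of the assay and not numbers.

Compound 2 stands at > 10000 nM as a limit, so it has no exact place in the series. Compound 3 `CCOC(=O)c1ccc(NCc2cncn2Cc2ccc(-c3ccccc3)cc2)cc1-c1ccccc1` carries ethoxy in place of ethyl on a carbonyl carbon and shares the rest of its structure with compound 2. Going by the values given here, the only measured step that bears on this change is a step that the two limits leave unreadable from compound 1 to compound 2 with ethyl in place of piperidin-1-yl on a carbonyl carbon. That step has no readable size, so it sets no size for the new change. In this assay no shift beyond the scatter is therefore expected, in either direction. The expected step is a step that the limit leaves unreadable from compound 2 to compound 3 on this estimate. For compound 3 the estimated value is 15000 nM with an expected range from 4000 nM to 50000 nM and a report as a limit is quite likely.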

Compound 3, half-maximal effective concentration: > 10000 nM
Compound 3: a limit, no number; the forecaster's own chance of this, stated with the estimate: 80%; the middle value lies beyond the limit too.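

In this assay compound 2 gives > 10000 nM, which is a limit of the assay. Compound 3 gives > 10000 nM, also a limit. No step can be read among compound 1, compound 2 and compound 3. Where their effects actually lie, and whether ethyl, ethoxy and piperidin-1-yl on a carbonyl carbon differ at all, stays open.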